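The compounds below may be only part of what the source reports. "The series", "measured", "known", "first", "only" and "open" are said of these compounds alone.

Compound 1 `COc1ccc2oc(=O)c(-c3ccc(Br)nn3)cc2c1` and compound 2 `Cc1ccc2oc(=O)c(-c3ccc(Cl)nn3)cc2c1` share a core and differ in two places. In an assay on cells for inhibition of Amine oxidase [flavin-containing] B (Homo sapiens), read by fluorescence and Amplex Red, with a stated time of 15 min (a higher number here means a weaker inhibitor, a lower number a stronger inhibitor), compound 1 gives 560 nM, while compound 2 gives 13500 nM, the higher of the two numbers and, by the gap to compound 1, a clearly weaker inhibitor. Compound 3 `COc1ccc2oc(=O)c(-c3ccc(Cl)nn3)cc2c1` is compound 2 with one change: methoxy in place of methyl on an aromatic carbon. Going by the values given here, no single step of this kind has been measured here, so the size of the change is uncertain. A step from compound 2 to compound 3 of a 9.0-fold lower number from compound 2 to compound 3 (0.95 log units; beyond the scatter) toward stronger inhibition is expected, since compound 3 then matches compound 1 apart from the halogen. For compound 3 in this assay a value of about 1500 nM is estimated, with a range from 400 nM to 6000 nM.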

Compound 3, half-maximal inhibitory concentration: 8800 nM
Compound 3: the middle estimate sits 5.9-fold (0.77 log units) below what was measured; measured number outside the range, above it.
By their numbers in this assay, from the lowest: compound 1; then compounds 3 and 2 (each within the scatter of the next).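

In this assay, methoxy in place of methyl on this aromatic carbon, with chloro kept, gives a 1.5-fold lower number from compound 2 to compound 3 (0.19 log units; within the scatter), so at this position the change does not separate the two compounds. The halogen step is the large one: chloro in place of bromo gives a 16-fold higher number from compound 1 to compound 3 (1.20 log units; beyond the scatter), which shows that the halogen matters strongly in this series. Nothing measured here accounts for the size of that step. From the compounds shown here alone, whether methyl and methoxy would also stay within the scatter with bromo in place of chloro remains open. So does the effect of an amine or a fluorine at the halogen's carbon.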